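Two Fluorophenyl Placements on Related Dienone Cores

A few compounds are considered here, and "the series" means these few. Any claim that something is new, unique, unknown or untested is made for them only; others in the source may bear on it.

Measured compounds:
Compound 1, `COc1cc(/C=C2\CN(C)C/C(=C\c3ccccc3F)C2=O)cc(OC)c1OC`, gives 4340 nM.
Compound 2, `CN1C/C(=C\c2ccc(C#N)cc2)C(=O)/C(=C/c2ccccc2F)C1`, gives 2670 nM.
Compound 3, `COc1cc(/C=C2\CN(C)C/C(=C\c3ccc(F)cc3)C2=O)cc(OC)c1OC`, gives 10300 nM.

The three compounds were tested in a functional assay on K562 cells (Homo sapiens) for cytotoxicity, read by MTT assay, with a stated time of 24 h; a higher number here means a weaker inhibitor, a lower number a stronger inhibitor. Compound 1 and compound 3 share one core and differ in a single place: 4-fluorophenyl in place of 2-fluorophenyl on a double-bonded chain carbon bound to a double-bonded ring carbon. This change produced a 2.4-fold higher number from compound 1 to compound 3 (0.38 log units; beyond the scatter), a step that lies beyond the scatter of the method.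

Compound 2 is built on a second core. The difference between the two cores is not broken down here. Compound 2 and compound 1 give numbers within the scatter of each other, so no order between them is claimed. Against compound 3, compound 2 gives the lower number, and that gap lies beyond the scatter.

Compound 4, `CN1C/C(=C\c2ccc(F)cc2)C(=O)/C(=C/c2ccc(C#N)cc2)C1`, has not yet been measured in this assay. It stands to compound 2 as compound 3 stands to compound 1: 4-fluorophenyl in place of 2-fluorophenyl on a double-bonded chain carbon bound to a double-bonded ring carbon. The place is described in the same words for both pairs, so this is the same kind of change made on a different core. Within the data shown here, on that basis the step is expected to be a 2.4-fold higher number from compound 2 to compound 4 (0.38 log units; beyond the scatter), resting on the one measured example, a 2.4-fold higher number from compound 1 to compound 3 (0.38 log units; beyond the scatter), with the caution that a single pair on another core is a thin footing. Compound 4 is therefore estimated to give 6400 nM in this assay, with an expected range from 2700 nM to 15000 nM.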

Compound 4, half-maximal inhibitory concentration: 11300 nM
The estimate for compound 4 lay 1.8-fold (0.25 log units) below the measured number; measured number inside the range.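

In this assay, putting 4-fluorophenyl in place of 2-fluorophenyl on the core of compound 2 gave a 4.2-fold higher number from compound 2 to compound 4 (0.63 log units; beyond the scatter). Set beside the earlier example, the step points the same way on both cores, and its size on the two cores cannot be told apart: the same change on two cores in this assay, a 2.4-fold higher number (0.38 log units; beyond the scatter) from compound 1 to compound 3 and a 4.2-fold higher number (0.63 log units; beyond the scatter) from compound 2 to compound 4, 1.8-fold (0.25 log units) apart, within the scatter of two such steps. Among these compounds, the change therefore carried over from one core to the other in direction and, as far as this method can separate the two steps, in size, but this rests on only two pairs in a single cell assay and shows neither why the number rises nor whether a third core would behave the same way.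

The two cores shown differ in their other aromatic group, a trimethoxyphenyl in compound 1 and compound 3 and a nitrile-bearing phenyl in compound 2 and compound 4, so it remains open whether the step would persist with an amine or a carboxylic acid on that ring. On these data alone, it also remains open how a chlorophenyl or an unsubstituted phenyl would compare with the two fluorophenyl groups, or whether a longer chain in place of the methyl on the ring nitrogen would alter the step.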